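This account rests on a few compounds, and the source may have more. Where it says the series, first, only, none or still open, it means among the compounds named here.

Measured in a functional assay on MCF7 cells (Homo sapiens) for cytotoxicity, read by MTT assay, with a stated time of 72 h; a lower number here means a stronger inhibitor, a higher number a weaker inhibitor:
- Compound 1 `O=C1c2c[n+]([O-])c3ccccc3c2C(=O)c2c1c1ccccc1n2Cc1cn([C@@H]2C[C@H](O)[C@@H](CO)O2)nn1`: 110 nM
- Compound 2 `O=C1c2c[n+]([O-])c3ccccc3c2C(=O)c2c1c1ccccc1n2Cc1cn(CC(O)CO)nn1`: 1110 nM

Not yet measured:
- Compound 3 `O=C1c2c[n+]([O-])c3ccccc3c2C(=O)c2c1c1ccccc1n2Cc1cn([C@H]2C[C@H](O)[C@@H](CO)O2)nn1`

Compound 2, at 1110 nM, has the higher of the two numbers, so it is the weaker inhibitor. Compound 3 brings 4-hydroxy-5-(hydroxymethyl)oxolan-2-yl in place of 2,3-dihydroxypropyl on an aromatic nitrogen. Going by the values given here, the one measured step that bears on this is a 10-fold higher number from compound 1 to compound 2 (1.00 log units; beyond the scatter), which ran the opposite way. Compound 3 carries that group with a different spatial arrangement from compound 1, and no measurement shows what this does. A drop in this assay of similar or somewhat smaller size is therefore expected. The estimated change is a 5.6-fold lower number from compound 2 to compound 3 (0.74 log units; beyond the scatter). The expected value for compound 3 is 200 nM, within a range of 70 nM to 600 nM.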

Compound 3, half-maximal inhibitory concentration: 530 nM
Compound 3: middle estimate off by 2.7-fold (0.42 log units), on the low side; the range from low to high includes it.
By their numbers in this assay, from the lowest: compound 1; then compound 3; then compound 2.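

In this assay, the 4-hydroxy-5-(hydroxymethyl)oxolan-2-yl group still beats 2,3-dihydroxypropyl with its stereocentre changed, with a 2.1-fold lower number from compound 2 to compound 3 (0.32 log units; beyond the scatter). Configuration at this position also counts, with a 4.8-fold higher number from compound 1 to compound 3 (0.68 log units; beyond the scatter). That gap can be traced to one stereocentre at a saturated ring carbon, because nothing else changes: the fact that compounds 1 and 3 differ only in the configuration as drawn

Going by these compounds, how the other two stereocentres of the ring affect the number stays open. So does whether an amine in place of the ring hydroxyl, or a longer chain in place of hydroxymethyl, would keep the number of compound 1.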